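The compounds below may be only part of what the source reports. "The series", "measured", "known", "first", "only" and "open" are said of these compounds alone.

Compound 1 `CN(Cc1cccnc1)C(=S)SCc1ccc(C(=O)Nc2ccccc2N)cc1` is the point of departure. In a functional assay on HeLa cells (Homo sapiens) for antiproliferative activity, read by CCK-8 assay, with a stated time of 72 h, tested at 2 uM (a higher number here means a stronger effect of the compound at the concentration tested, a lower number a weaker effect), compound 1 gives 16.4%, the lowest of the three numbers recorded. Compound 3 `Nc1ccccc1NC(=O)c1ccc(CSC(=S)N2CCCC2)cc1` gives 51.3% in this assay, and compound 2 `Nc1ccccc1NC(=O)c1ccc(CSC(=S)N2CCN(Cc3ccncc3)CC2)cc1` gives 59.5% in this assay; both stand beyond the scatter above compound 1.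

Compound 4 `CN1CCN(C(=S)SCc2ccc(C(=O)Nc3ccccc3N)cc2)CC1` has not yet been measured. It differs from compound 1 in one place: 4-methylpiperazin-1-yl in place of methyl((pyridin-3-yl)methyl)amino on a thiocarbonyl carbon. Going by the values given here, the one measured step that bears on this change is the one from compound 1 to compound 3, where a cyclic amine likewise replaces the open-chain methyl((pyridin-3-yl)methyl)amino on the thiocarbonyl carbon: a number 34.9 percentage points higher from compound 1 to compound 3 (beyond the scatter). Compound 2, which also carries a cyclic amine on that carbon, is the highest of the three. On that basis compound 4 is expected to move upward by a step of about a number 33.6 percentage points higher from compound 1 to compound 4 (beyond the scatter) in this assay, beyond the scatter. The estimate for compound 4 in this assay is 50%, with a range from 30% to 70%.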

Compound 4, a percentage reported as inhibition, at one concentration (the size of the read-out at that concentration, not a potency): 52.6%
Estimate against measurement, compound 4: 2.6 percentage points below; the measured number falls inside the stated range.
By their numbers in this assay, from the lowest: compound 1; then compounds 3, 4 and 2 (each within the scatter of the next).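

In this assay, 4-methylpiperazin-1-yl in place of methyl((pyridin-3-yl)methyl)amino on the thiocarbonyl carbon gives a number 36.2 percentage points higher from compound 1 to compound 4 (beyond the scatter), so the large rise no longer rests on pyrrolidin-1-yl alone. Exchanging pyrrolidin-1-yl for 4-methylpiperazin-1-yl gives a number 1.3 percentage points higher from compound 3 to compound 4 (within the scatter), and hydrogen in place of pyridin-4-yl on the saturated chain carbon gives a number 6.9 percentage points lower from compound 2 to compound 4 (within the scatter), so neither the choice between these two rings nor the pyridin-4-yl group shows a difference beyond the scatter. No measurement here explains these steps.

Both large steps from compound 1 replace the open-chain amine with a ring and remove its pyridin-3-yl group at once, so the compounds shown cannot separate those two changes. A dimethylamino group or a benzyl(methyl)amino group on the thiocarbonyl carbon would bear on that question, and the read-out at one concentration leaves potency open.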